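The source may hold more compounds than are shown below. What is called first, only, known or untested is meant among the compounds shown, and "the series" means these compounds.

In a functional assay on HepG2 cells (Homo sapiens) for inhibition, read by MTT assay, with a stated time of 72 h (on this read-out higher numbers stand for weaker inhibition and lower numbers for stronger inhibition), compound 2 `Fc1ccc(-c2nnc(SCCCN3CCN(c4nc5ccccc5s4)CC3)o2)cc1` gives 234000 nM and compound 1 `COc1ccc(-c2nnc(SCCCN3CCN(c4nc5ccccc5s4)CC3)o2)cc1` gives 134000 nM so the two sit within the usual scatter of each other and neither can be ranked above the other. Compound 3 `O=C(NCc1nnc(SCCCN2CCN(c3nc4ccccc4s3)CC2)o1)c1ccccc1` differs from compound 2 by benzamidomethyl in place of 4-fluorophenyl on an aromatic carbon. Within the data shown here, only one measured step bears on this: a 1.7-fold higher number from compound 1 to compound 2 (0.24 log units; within the scatter) when fluoro replaces methoxy on an aromatic carbon. That step is small, but it is a weak guide, as it swaps one small group while the new change replaces a whole group. No step beyond the scatter is therefore expected in this assay in either direction. The expected change, a 1.6-fold lower number from compound 2 to compound 3 (0.19 log units; within the scatter) is an estimate with an uncertain direction. For compound 3 the estimated value is 150000 nM with an expected range from 50000 nM to 400000 nM (an estimate, not a measurement).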

Compound 3, half-maximal inhibitory concentration: 325000 nM
Estimate against measurement, compound 3: 2.2-fold (0.34 log units) below; the range from low to high includes it.
By their numbers in this assay, from the lowest: compounds 1, 2 and 3 (each within the scatter of the next, the first and the last beyond it).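

In this assay, putting benzamidomethyl in place of 4-fluorophenyl on this ring carbon gives a 1.4-fold higher number from compound 2 to compound 3 (0.14 log units; within the scatter), so this much larger swap, which adds a hydrogen-bond donor and a hydrogen-bond acceptor, still cannot be told apart from the earlier compound. Among these compounds, the same benzamidomethyl group in place of 4-methoxyphenyl gives a 2.4-fold higher number from compound 1 to compound 3 (0.38 log units; beyond the scatter), the first modest step in this small set that clears the scatter, and it points towards weaker inhibition. No measurement is available that could explain either step.

Each group tested so far at this position carries a six-membered aromatic ring of carbon. On these data alone, whether a simple amine or a carboxylic acid there, or a longer chain in place of the methylene link in benzamidomethyl, would shift the number in either direction remains open.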